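From thiophen-3-yl to 1-benzofuran-2-yl on the shared core

The compounds below may be only part of what the source reports. "The series", "measured", "known", "first", "only" and "open" are said of these compounds alone.

- Compound 1 `COc1nc(N)nc2c1c(-c1cccs1)cn2[C@@H]1O[C@H](CO)[C@@H](O)[C@H]1O`: > 100000 nM (a limit)
- Compound 2 `COc1nc(N)nc2c1c(-c1ccsc1)cn2[C@@H]1O[C@H](CO)[C@@H](O)[C@H]1O`: > 100000 nM (a limit)

Both results come from an ADME assay on MRC5 cells (Homo sapiens), read by MTT assay, with a stated time of 72 h; on this read-out higher numbers stand for weaker inhibition and lower numbers for stronger inhibition. Compound 2 stands at > 100000 nM, which is a limit of the assay and not a number. The two compounds share (the limit of > 100000 nM in this assay, at which 2 of the 2 values shown sit), so neither can be ranked against the other. Within the data shown here, the only measured step is a step that the two limits leave unreadable from compound 1 to compound 2, and it offers no size to carry forward.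

Compound 3 `COc1nc(N)nc2c1c(-c1cc3ccccc3o1)cn2[C@@H]1O[C@H](CO)[C@@H](O)[C@H]1O` keeps the shared core and changes one group on an aromatic carbon: 1-benzofuran-2-yl in place of thiophen-3-yl on an aromatic carbon. Here 1-benzofuran-2-yl takes the place of thiophen-3-yl. Among the measured compounds shown here, no measured step involves this group, so any forecast is loose. In this assay, the expectation is that compound 3 stays close to the limit, with some room for a move towards stronger inhibition, meaning a lower number. The estimated move is an at least 1.1-fold lower number from compound 2 to compound 3 (0.04 log units; that floor lies within the scatter). For compound 3 the expected value is 90000 nM, with an estimated range from 30000 nM to 100000 nM.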

Compound 3, half-maximal inhibitory concentration: 22700 nM
The estimate for compound 3 lay 4.0-fold (0.60 log units) above the measured number; measured number outside the range, below it.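

In this assay, among these compounds, compound 3 gives the first reading in this set that is a number and not a limit, so a group at this aromatic carbon of the shared core can shift the result into the measurable range. Replacing either thiophene with 1-benzofuran-2-yl, which brings a further six-membered aromatic ring of carbon only and an oxygen in place of the sulfur, gives an at least 4.4-fold lower number from compound 2 to compound 3 (0.64 log units; beyond the scatter) and also an at least 4.4-fold lower number from compound 1 to compound 3 (0.64 log units; beyond the scatter). Both steps are floors and not full sizes, yet they can be read as a move towards stronger inhibition, whereas the step between the two thiophene compounds cannot be read, since those compounds share one limit: the limit of > 100000 nM in this assay, at which 2 of the 3 values shown sit.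

The compounds shown change the added ring and the ring hetero atom together, so they do not tell which of the two carries the step, and a 1-benzothiophen-2-yl group, which keeps the sulfur and adds the ring, would bear directly on that. As far as these compounds go, how far the number moves with other groups at this place, such as a simple phenyl ring or an amine, also stays open.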